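The source may report more compounds than this note shows. Statements on the series, on what has been measured and on what is new or still open speak of the compounds shown alone.

Working notes on the series, step from compound 2 to compound 4.

Compound 2 `CNc1nc(Cl)nc(N[C@@H](C)c2ccccc2)n1` gives the highest number of the three measured in an ADME assay on the whole organism for inhibition, with Echinochloa crus-galli var. formosensis as the target, with a stated time of 4 days (on this read-out lower numbers stand for stronger inhibition and higher numbers for weaker inhibition), at 26900 nM. Compound 1 `CCN(c1nc(Cl)nc(N[C@@H](C)c2ccccc2)n1)C(C)C` gives 229 nM in this assay, and compound 3 `CCN(CC)c1nc(Cl)nc(NC(C)c2ccccc2)n1` gives 1510 nM; against compound 2 both stand far lower, well beyond the scatter.

Compound 4 `C[C@H](Nc1nc(Cl)nc(NC(C)(C)C)n1)c1ccccc1` is not yet measured. The change from compound 2 is tert-butyl in place of methyl on a nitrogen on an aromatic ring. For the measured compounds named here, the one step that bears on it is a 120-fold higher number from compound 1 to compound 2 (2.07 log units; beyond the scatter), where the move to methylamino on the shared core ran with the large rise in the number. Going by the values given here, the change toward compound 4 runs the other way from methylamino, so a drop in the number is expected in this assay, though no measured pair shows a (tert-butyl)amino group itself and the pair of compound 1 and compound 3 only shows that the two dialkylamino groups differ from each other.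

The expected step is a 67-fold lower number from compound 2 to compound 4 (1.83 log units; beyond the scatter). For compound 4 the estimate is 400 nM, with a range from 100 nM to 2500 nM.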

Compound 4, half-maximal inhibitory concentration: 7410 nM
Estimate against measurement, compound 4: 19-fold (1.27 log units) below; the whole stated range lies below it.
By their numbers in this assay, from the lowest: compound 1; then compound 3; then compound 4; then compound 2.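

In this assay, a 3.6-fold lower number from compound 2 to compound 4 (0.56 log units; beyond the scatter) shows that replacing methyl with tert-butyl on this nitrogen lowers the number, but only modestly. A wide gap remains to the ethyl(isopropyl)amino group, with a 32-fold higher number from compound 1 to compound 4 (1.51 log units; beyond the scatter) on the shared core, so a (tert-butyl)amino group at this place does not come close to compound 1. Nothing on hand explains why these amino groups differ.

Going by these compounds, it remains open whether an ethylamino or isopropylamino group at this place would stand nearer to compound 4 or to compound 1, and whether a dialkylamino group is needed for the lowest numbers. A cyclopropylamino group, a longer chain such as n-butylamino, or a ring amine such as piperidine would also test how far the trend among these amino groups extends.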